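Replacing the Acid-Bearing Ring with a Diamine Chain

The source may report more compounds than this note shows. Statements on the series, on what has been measured and on what is new or still open speak of the compounds shown alone.

Measured so far:
compound 1 `COc1ccc(/C=C\c2cc(OC)c(OC)c(OC)c2)cc1OCc1ccc(CN2CCCC[C@H]2C(=O)O)cc1` — > 10000 nM
compound 2 `COc1ccc(/C=C\c2cc(OC)c(OC)c(OC)c2)cc1OCc1ccc(CN2CCCCC2C(=O)O)cc1` — 5400 nM
compound 3 `COc1ccc(/C=C\c2cc(OC)c(OC)c(OC)c2)cc1OCc1ccc(CN[C@H](C(=O)O)[C@H](C)O)cc1` — > 10000 nM

Of the compounds shown here, three built on the shared core have been tested in a functional assay on MC-38 cells (Mus musculus) for antiproliferative activity, read by CCK-8 assay, with a stated time of 48 h; on this read-out lower numbers stand for stronger inhibition and higher numbers for weaker inhibition. Compound 1 reaches only the limit of this assay, > 10000 nM, so its standing among the numbers shown is a limit rather than a value. Compound 3 also stops at the limit, > 10000 nM. For the measured compounds named here, compound 2 is the one compound with a number, 5400 nM. The step of an at least 1.8-fold lower number from compound 1 to compound 2 (0.26 log units; that floor lies within the scatter) is tied to the fact that one of compounds 1 and 2 is drawn with a defined configuration and the other without, at the place where they differ, and the step of an at least 1.8-fold higher number from compound 2 to compound 3 (0.26 log units; that floor lies within the scatter) changes the group on the saturated chain carbon bound to the aromatic carbon. The step that the two limits leave unreadable from compound 1 to compound 3 cannot be sized because of the limit of > 10000 nM in this assay, at which 2 of the 3 values shown sit.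

Compound 4 `COc1ccc(/C=C\c2cc(OC)c(OC)c(OC)c2)cc1OCc1ccc(CNCCN(C)C)cc1` is not yet measured. Relative to compound 1 the change is (2-(dimethylamino)ethyl)amino in place of 2-carboxypiperidin-1-yl on a saturated chain carbon bound to an aromatic carbon. The steps from compound 1 to compound 3 and from compound 2 to compound 3 alter the same position, but neither introduces this chain, and both give at most a small or unreadable shift. Compound 4 is therefore expected to move only modestly, the step of an at least 2.5-fold lower number from compound 1 to compound 4 (0.39 log units; beyond the scatter) being the estimate. Compound 4 is estimated at 4000 nM, within 800 nM to 20000 nM.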

Compound 4, half-maximal inhibitory concentration: 1400 nM
Beside the measured number, compound 4's estimate is 2.9-fold (0.46 log units) above it, and the stated range covers the measured number.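

In this assay, for the compounds shown here, the exchange of 2-carboxypiperidin-1-yl for (2-(dimethylamino)ethyl)amino on a saturated chain carbon bound to an aromatic carbon gives a 3.9-fold lower number from compound 2 to compound 4 (0.59 log units; beyond the scatter) and so yields the first step at this position that lies beyond the scatter and joins two actual numbers. Measured against the other two compounds, the change reads as an at least 7.1-fold lower number from compound 1 to compound 4 (0.85 log units; beyond the scatter) and as an at least 7.1-fold lower number from compound 3 to compound 4 (0.85 log units; beyond the scatter) but these two steps are floors and not sizes: the limit of > 10000 nM in this assay, at which 2 of the 4 values shown sit. Compound 4, the only compound shown without a carboxylic acid, is the strongest of the four, so this position tolerates more than the earlier compounds could reveal and the entering chain, which has no ring, can improve on all three acid-bearing groups.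

The compounds shown do not separate the loss of the carboxylic acid from the gain of the dimethylamino group, a question that a plain piperidine ring or a chain ending in a primary amine would address. They also leave open whether a longer chain ending in the same dimethylamino group would go further.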